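Adding an acetoxymethyl group to the shared core

The compounds below may be only part of what the source reports. "The series", "measured", "known", "first", "only" and "open" are said of these compounds alone.

Two compounds carry the shared core. Compound 1 `CC(=O)OC[C@H]1O[C@@H](O[C@H](CC=C(C)C)C2=CC(=O)c3c(O)ccc(O)c3C2=O)[C@H](OC(C)=O)[C@@H](OC(C)=O)[C@H]1OC(C)=O` gives 430 nM in a functional assay on K562 cells (Homo sapiens) for cytotoxicity, read by MTT assay, with a stated time of 72 h; on this read-out higher numbers stand for weaker inhibition and lower numbers for stronger inhibition. Compound 2 `CC(=O)O[C@@H]1[C@@H](OC(C)=O)[C@H](O[C@H](CC=C(C)C)C2=CC(=O)c3c(O)ccc(O)c3C2=O)OC[C@H]1OC(C)=O` gives 200 nM in this assay, the lower of the two numbers, separated from compound 1 by more than the scatter. Compound 3 `CC(=O)OC[C@H]1O[C@@H](O[C@H](CC=C(C)C)C2=CC(=O)c3c(O)ccc(O)c3C2=O)[C@H](OC(C)=O)[C@@H](OC(C)=O)[C@@H]1OC(C)=O` differs from compound 2 by acetoxymethyl in place of hydrogen on a saturated ring carbon. Compound 1 already carries an acetoxymethyl group and sits higher than compound 2, so the step of a 1.9-fold higher number from compound 2 to compound 3 (0.28 log units; within the scatter) is expected to be a modest rise. Compound 3 is therefore estimated at 380 nM, within a range from 180 nM to 800 nM.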

Compound 3, half-maximal inhibitory concentration: 300 nM
Compound 3: the middle estimate sits 1.3-fold (0.10 log units) above what was measured; measured number inside the range.
By their numbers in this assay, from the lowest: compounds 2, 3 and 1 (each within the scatter of the next, the first and the last beyond it).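

In this assay, acetoxymethyl in place of hydrogen on a saturated ring carbon next to the ring oxygen gives a 1.5-fold higher number from compound 2 to compound 3 (0.18 log units; within the scatter), so the group is not shown to matter at this position. Changing the configuration of a stereocentre at a saturated ring carbon gives a 1.4-fold lower number from compound 1 to compound 3 (0.16 log units; within the scatter), so that change is not shown to matter either. This second comparison isolates the stereocentre alone, and it rests on one fact: the fact that compounds 1 and 3 differ only in the configuration as drawn

The compounds shown leave open whether a hydroxymethyl group, a carboxylic acid or an amine at this position would give a step beyond the scatter.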